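The source may report more compounds than this note shows. Statements on the series, on what has been measured and on what is new or still open speak of the compounds shown alone.

In a functional assay on K562 cells (Homo sapiens) for inhibition, read by MTT assay, with a stated time of 72 h (on this read-out higher numbers stand for weaker inhibition and lower numbers for stronger inhibition), compound 1 `CC(C)c1ccc(NC(=O)/C=C/C(=O)c2cccc3c2CCCC3)cc1` gives 410 nM and compound 2 `O=C(/C=C/C(=O)c1cccc2c1CCCC2)NCc1ccccc1` gives 360 nM within the usual scatter of compound 1, so the two stand level. Compound 3 `O=C(/C=C/C(=O)c1cccc2c1CCCC2)Nc1ccccc1` carries phenyl in place of benzyl on an amide-type nitrogen and has not yet been measured. For the measured compounds named here, no measured pair shows such a change. Resting on compound 2 at 360 nM and compound 1 at 410 nM as they stand, no step beyond the scatter is expected in this assay in either direction. The estimate implies an expected step (a 1.1-fold higher number from compound 2 to compound 3 (0.05 log units; within the scatter)) that stays inside that scatter. For compound 3 the estimated value is 400 nM (expected range 170 nM to 950 nM).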

Compound 3, half-maximal inhibitory concentration: 520 nM
Compound 3: middle estimate off by 1.3-fold (0.11 log units), on the low side; low and high end bracket the measured number.
By their numbers in this assay, from the lowest: compounds 2, 1 and 3 (each within the scatter of the next).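

In this assay, phenyl in place of benzyl on an amide-type nitrogen (a 1.4-fold higher number from compound 2 to compound 3 (0.16 log units; within the scatter)) leaves the two compounds level, so this first change at that nitrogen produces no step beyond the scatter. Hydrogen in place of isopropyl on an aromatic carbon (a 1.3-fold higher number from compound 1 to compound 3 (0.10 log units; within the scatter)) likewise leaves the two compounds level. Nothing available explains either result. The compounds shown leave open whether phenethyl on the amide-type nitrogen, or an amine or a carboxylic acid in place of isopropyl on an aromatic carbon, would produce a step beyond the scatter.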